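The source may hold more compounds than are shown below. What is called first, only, known or untested is meant among the compounds shown, and "the series" means these compounds.

Working notes on the series: the shared core stays fixed while the group on the saturated ring carbon varies. In a functional assay on HepG2 cells (Homo sapiens) for antiproliferative activity, read by MTT assay, with a stated time of 48 h (on this read-out lower numbers stand for stronger inhibition and higher numbers for weaker inhibition), compound 1 `CC(=O)N1N=C(c2ccc3ccccc3c2)OC1c1ccccc1Br` gives 3.98 ug/mL, compound 2 `CC(=O)N1N=C(c2ccc3ccccc3c2)OC1c1cccc(Br)c1` gives 1.68 ug/mL and compound 3 `CC(=O)N1N=C(c2ccc3ccccc3c2)OC1c1ccccc1F` gives 3.36 ug/mL. Compound 3 sits level with the other two within the scatter, the steps to it being a 1.2-fold lower number from compound 1 to compound 3 (0.07 log units; within the scatter) and a 2.0-fold higher number from compound 2 to compound 3 (0.30 log units; within the scatter).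

Compound 4 `CC(=O)N1N=C(c2ccc3ccccc3c2)OC1c1cccnc1` is not yet measured. It carries pyridin-3-yl in place of 2-fluorophenyl on a saturated ring carbon. Among the measured compounds shown here, no measured step replaces a ring of carbon only with a ring holding a hetero atom, so the evidence is indirect. The largest change seen at this carbon, a 2.4-fold lower number from compound 1 to compound 2 (0.37 log units; beyond the scatter), is modest, and the other two steps stay within the scatter. No step beyond the scatter is therefore expected in this assay, and no direction is favoured.

The estimated step is a 1.0-fold higher number from compound 3 to compound 4 (0.02 log units; within the scatter). Compound 4 is expected at 3.5 ug/mL, with an estimated range from 1.4 ug/mL to 9 ug/mL.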

Compound 4, half-maximal inhibitory concentration: 2.86 ug/mL
Beside the measured number, compound 4's estimate is 1.2-fold (0.09 log units) above it, and the stated range covers the measured number.
By their numbers in this assay, from the lowest: compounds 2, 4, 3 and 1 (each within the scatter of the next, the first and the last beyond it).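

In this assay, pyridin-3-yl on the saturated ring carbon, the first ring here holding a hetero atom, sits level with all three halogen-bearing phenyl compounds (a 1.2-fold lower number from compound 3 to compound 4 (0.07 log units; within the scatter); a 1.7-fold higher number from compound 2 to compound 4 (0.23 log units; within the scatter); a 1.4-fold lower number from compound 1 to compound 4 (0.14 log units; within the scatter)). Among the compounds shown here, a ring without halogen and with a hydrogen-bond acceptor therefore opens no step beyond the scatter, and the only such step remains the one between the two bromophenyl compounds. Nothing measured here explains this flat response.

On these data alone, it remains open whether a pyridin-2-yl or pyridin-4-yl ring would behave in the same way, and whether an amine or a carboxylic acid on the ring would separate from this level. As far as these compounds go, a longer alkyl chain on this carbon, with no aromatic ring at all, is equally open.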